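A few compounds are considered here, and "the series" means these few. Any claim that something is new, unique, unknown or untested is made for them only; others in the source may bear on it.

Measured compounds in an ADME assay for permeability, using PAMPA, with a stated time of 30 min, at pH 7.4; on this read-out lower numbers stand for lower permeability and higher numbers for higher permeability:

- compound 1 `COc1cccc(Oc2ccc3c(NCCCNCc4cccc(OC)c4O)ccnc3c2)c1`: 317 10^-6 cm/s
- compound 2 `COc1cccc(CNCCCNc2ccnc3cc(Oc4cccc(N(C)C)c4)ccc23)c1O`: 317 10^-6 cm/s
- compound 3 `COc1cccc(CNCCCNc2ccnc3cc(Oc4ccc(F)cc4)ccc23)c1O`: 317 10^-6 cm/s

Compound 3 stands level with compound 1 and compound 2 on this read-out. The step of no change at the digits printed from compound 1 to compound 3 (within the scatter) and the step of no change at the digits printed from compound 2 to compound 3 (within the scatter) are both within the scatter, as is the step of no change at the digits printed from compound 1 to compound 2 (within the scatter) between the two compounds compared with it. Among the compounds with values here, on the numbers so far, none of the three compounds can be separated from the others.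

Compound 4 `COc1cccc(CNCCCNc2ccnc3cc(-c4ccccc4)ccc23)c1O` is the next compound to be measured. It differs from compound 3 in one place: phenyl in place of 4-fluorophenoxy on an aromatic carbon. Within the data shown here, no measured step exchanges a phenoxy group for a directly attached phenyl ring, so the closest guides are the changes at the same part of the shared core, the step of no change at the digits printed from compound 1 to compound 3 (within the scatter) and the step of no change at the digits printed from compound 2 to compound 3 (within the scatter), both of which left the value unchanged within the scatter. On that basis the expected step of no change at the digits printed from compound 3 to compound 4 (within the scatter) is none beyond the scatter. Compound 4 is therefore estimated at 317 10^-6 cm/s, with a range from 160 10^-6 cm/s to 630 10^-6 cm/s.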

Compound 4, apparent permeability: 237 10^-6 cm/s
Estimate against measurement, compound 4: 1.3-fold (0.13 log units) above, and the stated range covers the measured number.
By their numbers in this assay, from the lowest: compounds 4, 1, 2 and 3 (each within the scatter of the next).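

In this assay, within the data shown here, the new compound removes something the earlier steps left in place: those steps changed only the ring carried on the oxygen, while here the oxygen itself goes and a phenyl ring sits directly on the aromatic carbon, giving a 1.3-fold lower number from compound 3 to compound 4 (0.13 log units; within the scatter) for an exchange that also removes the fluorine. Read against the two other phenoxy compounds, the same kind of exchange gives a 1.3-fold lower number from compound 2 to compound 4 (0.13 log units; within the scatter) and a 1.3-fold lower number from compound 1 to compound 4 (0.13 log units; within the scatter) as its results. So at this position of the shared core, this assay does not separate a directly attached phenyl from any of the three phenoxy groups, and the oxygen link and the substituents on the phenoxy ring make no difference that can be read from these four compounds.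

Nothing available here accounts for this outcome. The compounds shown leave open whether the number would hold with a quite different group at this position, such as an amine, a carboxylic acid or a longer carbon chain, since every group so far carries a six-membered aromatic ring of carbon only.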